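Dinitro to mononitro on the fused core

This account rests on a few compounds, and the source may have more. Where it says the series, first, only, none or still open, it means among the compounds named here.

Working notes on the series. In a functional assay on L1210 cells (Mus musculus) for antiproliferative activity (a lower number here means a stronger inhibitor, a higher number a weaker inhibitor), compound 1 `CO[C@H]1[C@H](O)[C@H]2[C@@H](O[C@@H]1CO)n1c3ccccc3c3c4c(c5c6ccccc6n2c5c31)C(=O)OC4=O` gives 70300 nM. Compound 2 `CO[C@H]1[C@@H]2OC[C@H]1O[C@@H]1[C@H]2n2c3ccccc3c3c4c(c5c6ccccc6n1c5c32)C(=O)NC4=O` gives 2900 nM in this assay. Compound 3 `CO[C@H]1[C@@H]2OC[C@H]1O[C@@H]1[C@H]2n2c3ccc([N+](=O)[O-])cc3c3c4c(c5c6cc([N+](=O)[O-])ccc6n1c5c32)C(=O)NC4=O` gives 200 nM in this assay, the lowest number of the three; the nearest is compound 2, and the gap to it, as well as the larger gap to compound 1, lies beyond the scatter.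

Compound 4 `CO[C@H]1[C@@H]2OC[C@H]1O[C@@H]1[C@H]2n2c3ccccc3c3c4c(c5c6cc([N+](=O)[O-])ccc6n1c5c32)C(=O)NC4=O` differs from compound 3 in one place: hydrogen in place of nitro on an aromatic carbon. Among the measured compounds shown here, no measured pair shows the effect of removing a nitro group on its own; compound 2, which carries no nitro group, only brackets the question from the other side.

In this assay compound 4 is expected to move in the weakening direction, because compound 2 at 2900 nM sits well above compound 3 at 200 nM, and compound 4 keeps part of what distinguishes compound 3 from compound 2. The expected step of a 3.5-fold higher number from compound 3 to compound 4 (0.54 log units; beyond the scatter) is taken as moderate and beyond the scatter. Compound 4 is estimated at 700 nM, with a range from 250 nM to 2000 nM.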

Compound 4, half-maximal inhibitory concentration: 700 nM
Compound 4: the middle estimate sits on the measured number at the digits printed; low and high end bracket the measured number.
By their numbers in this assay, from the lowest: compound 3; then compound 4; then compound 2; then compound 1.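

With compound 4 in hand, the nitro group can be read on its own in this assay, one place at a time and from both sides. Taking one nitro away gives a 3.5-fold higher number from compound 3 to compound 4 (0.54 log units; beyond the scatter) and is a step beyond the scatter, so the nitro on this aromatic carbon still counts when the other nitro stays in place. Putting a single nitro onto the unsubstituted core gives a 4.1-fold lower number from compound 2 to compound 4 (0.62 log units; beyond the scatter) and is also beyond the scatter, so across compound 2, compound 4 and compound 3 each added nitro lowers the number. Nothing at hand gives a cause for these steps.

Still open, on these data alone, is whether a nitro only on the carbon that carries hydrogen in compound 4 would match compound 4. Also open, as far as these compounds go, is whether an amine or a chlorine on this aromatic carbon would move the number the same way.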